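A few compounds are considered here, and "the series" means these few. Any claim that something is new, unique, unknown or untested is made for them only; others in the source may bear on it.

Measured compounds:
compound 1 `COc1cc(NC(=O)Nc2cc(Nc3cccc(C(C)(C)C)c3)ncn2)cc(OC)c1` gives 48.7% in a functional assay on HCC827 cells (Homo sapiens) for inhibition, read by MTT assay, with a stated time of 48 h, tested at 10 uM; a higher number here means more inhibition at the concentration tested (going by the name of the read-out), a lower number less inhibition
compound 2 `COc1cc(Br)ccc1Nc1cc(NC(=O)Nc2c(Cl)cccc2Cl)ncn1` gives 42.7% in this assay
compound 3 `COc1cc(NC(=O)Nc2cc(Nc3ccc(Br)cc3OC)ncn2)cc(OC)c1` gives 57.7% in this assay

Compounds 3 and 2 differ in one place (2,6-dichlorophenyl in place of 3,5-dimethoxyphenyl on an amide-type nitrogen), and this change made a step of a number 15 percentage points lower from compound 3 to compound 2 (beyond the scatter). Compound 1 has a different core from compound 3; the difference is 3-(tert-butyl)phenyl in place of 4-bromo-2-methoxyphenyl on a nitrogen on an aromatic ring, and it went with a number 9 percentage points higher from compound 1 to compound 3 (within the scatter), which stays within the usual scatter. The values of compound 1 and compound 2 also lie within the scatter of each other.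

Compound 4 `CC(C)(C)c1cccc(Nc2cc(NC(=O)Nc3c(Cl)cccc3Cl)ncn2)c1` has not been measured. Within the data shown here, it differs from compound 1 by 2,6-dichlorophenyl in place of 3,5-dimethoxyphenyl on an amide-type nitrogen, which is the same change as the one made from compound 3 to compound 2, at a place described in the same words. Among the measured compounds shown here, for compound 1 to compound 4 a step of about a number 14.7 percentage points lower from compound 1 to compound 4 (beyond the scatter) is expected, resting on the earlier step of a number 15 percentage points lower from compound 3 to compound 2 (beyond the scatter), with added uncertainty because only one example of the change is known. Compound 4 is therefore estimated at 34%, between 20% and 50%.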

Compound 4, a percentage reported as inhibition, at one concentration (the size of the read-out at that concentration, not a potency): 37.3%
Estimate against measurement, compound 4: 3.3 percentage points below, and the stated range covers the measured number.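

Putting 2,6-dichlorophenyl in place of 3,5-dimethoxyphenyl on the amide-type nitrogen gave a number 11.4 percentage points lower from compound 1 to compound 4 (beyond the scatter) in this assay. Set beside the earlier example, the change gives a step of much the same size on both cores, so in these two cases it carries over from one core to the other: the same change on two cores in this assay, a number 15 percentage points lower (beyond the scatter) from compound 3 to compound 2 and a number 11.4 percentage points lower (beyond the scatter) from compound 1 to compound 4, 3.6 percentage points apart, within the scatter of two such steps. This rests on just two pairs of compounds, each read at a single concentration, so it does not show that the change would behave the same way on every core in the series, and it does not explain why the number falls.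

The compounds shown leave open what other groups would do on the amide-type nitrogen, such as a phenyl ring carrying an amine or a carboxylic acid, or a longer alkyl chain in place of the ring. They also leave open whether the step would keep its size with a third group on the other nitrogen, for example a pyridine ring.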